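A few compounds are considered here, and "the series" means these few. Any claim that something is new, unique, unknown or untested is made for them only; others in the source may bear on it.

Three compounds of the series have numbers in a functional assay on PC-3 cells (Homo sapiens) for cytotoxicity, read by sulforhodamine B assay, with a stated time of 48 h; a higher number here means a weaker inhibitor, a lower number a stronger inhibitor. Compound 1 `CC(=O)N1N=C(c2ccc(Br)cc2)CC1c1cccc(Cl)c1Cl` gives 38800 nM. Compound 2 `COc1ccc(C2CC(c3ccco3)=NN2C(C)=O)cc1OC` gives 12300 nM. Compound 3 `CC(=O)N1N=C(c2cccc3ccccc23)CC1c1ccccc1` gives 8460 nM, the lowest of the three numbers; against compound 2 the gap is within the scatter, so nothing separates those two, while against compound 1 the gap is beyond the scatter. Among the compounds with values here, no pair of measured compounds differs in a single place, so no step has yet been isolated within the set.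

Compound 4 `CC(=O)N1N=C(c2cccc3ccccc23)CC1c1ccco1` has not been measured. It differs from compound 3 in one place: furan-2-yl in place of phenyl on a saturated ring carbon. Within the data shown here, the measured set contains no step for this exchange on this carbon. Compound 2 carries a furan-2-yl on another position of the shared core, together with further changes, and its value sits within the scatter of compound 3; this is a weak hint only and does not isolate the furan ring. For compound 4 the expected step is a 1.2-fold higher number from compound 3 to compound 4 (0.07 log units; within the scatter), small, in either direction, and probably not beyond the scatter. The estimate for compound 4 in this assay is 10000 nM, with a range from 4000 nM to 25000 nM.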

Compound 4, half-maximal inhibitory concentration: 18000 nM
Beside the measured number, compound 4's estimate is 1.8-fold (0.26 log units) below it; the measured number falls inside the stated range.
By their numbers in this assay, from the lowest: compounds 3, 2 and 4 (each within the scatter of the next, the first and the last beyond it); then compound 1.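

In this assay the saturated ring carbon next to the ring atom that bears an acetyl group now has its first isolated step, with furan-2-yl in place of phenyl giving a 2.1-fold higher number from compound 3 to compound 4 (0.33 log units; beyond the scatter). The exchange therefore registers at this position, although the step is modest and the phenyl compound holds the lower number, so this carbon shows some sensitivity to which aromatic ring it carries, with the rest of the structure unchanged. The exchange removes one heavy atom and adds a hydrogen-bond acceptor, but no measurement accompanies the step that could separate these differences or account for the rise in the number.

Every compound shown carries an aromatic ring on this carbon, so the outcome with a saturated ring such as cyclohexyl, a longer alkyl chain, an amine or a carboxylic acid remains open. Going by these compounds, it is also open whether the same exchange would give a step of similar size and direction with a different group in place of the large group elsewhere on the shared core.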